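The compounds below may be only part of what the source reports. "The series", "measured", "known", "first", "only" and "open" are said of these compounds alone.

Measured so far:
compound 1 `CC(C)(C)C(=O)N1Cc2c(NC(=O)c3ccc(F)cc3)n[nH]c2C1(C)C` — 270 nM
compound 2 `CN1CCC(C(=O)N2Cc3c(NC(=O)c4ccc(Cl)cc4)n[nH]c3C2(C)C)CC1` — 120 nM

In a functional assay on A2780 cells (Homo sapiens) for antiproliferative activity, read by fluorescence, with a stated time of 72 h (on this read-out lower numbers stand for stronger inhibition and higher numbers for weaker inhibition), compound 2 gives the lower of the two numbers shown; compound 1 gives the higher one, and the gap between them lies beyond the usual scatter. The two measured compounds differ in more than one place, so no single-change step between measured compounds is available, and nothing is known directly about the size of a change of this kind in this assay.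

Compound 3 `CN1CCC(C(=O)N2Cc3c(NC(=O)c4ccccc4)n[nH]c3C2(C)C)CC1` is the next to be measured. Relative to compound 2 the change is hydrogen in place of chloro on an aromatic carbon.

Among the measured compounds shown here, since no measured step informs this change, the expectation rests on compound 2 alone: a modest rise in the number, close to the edge of the scatter, with weaker inhibition more likely than stronger. The expected step from compound 2 to compound 3 is a 1.8-fold higher number from compound 2 to compound 3 (0.26 log units; within the scatter). Compound 3 is therefore estimated at 220 nM in this assay, with a range from 90 nM to 550 nM.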

Compound 3, half-maximal inhibitory concentration: 160 nM
For compound 3 the middle estimate is 1.4-fold (0.14 log units) above the measured one; low and high end bracket the measured number.
By their numbers in this assay, from the lowest: compounds 2, 3 and 1 (each within the scatter of the next, the first and the last beyond it).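

In this assay, among the compounds shown here, the change from 4-chlorophenyl to phenyl gives the first single-change step, a 1.3-fold higher number from compound 2 to compound 3 (0.12 log units; within the scatter). At this place on the aromatic ring, para to a large group, chloro and hydrogen therefore cannot be told apart by this read-out, and the chloro is not needed for a value in this range. No supporting data bear on this result, and it carries no explanation.

As far as these compounds go, whether a larger or different group at this place, such as methoxy, nitrile, a primary amine or a carboxylic acid, would shift the number beyond the scatter remains open. The fluoro of compound 1 cannot be set against either result, as that compound also differs in its acyl group on the core.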